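The source may hold more compounds than are shown below. What is called first, only, known or untested is meant among the compounds shown, and "the series" means these compounds.

Compound 1 `CC(C)C[C@H](N)c1cc(C(F)(F)F)ccc1N1CCN(C(=O)COc2ccc3ccccc3c2)CC1`: 2000 nM
Compound 2 `CC(C)C[C@H](N)c1cc(Cl)ccc1N1CCN(C(=O)C(C)Cc2ccc(Cl)cc2)CC1`: 67 nM
Compound 3 `CC(C)C[C@H](N)c1cc(C(F)(F)F)ccc1N1CCN(C(=O)[C@H](C)Cc2ccc(Cl)cc2)CC1`: 31 nM

All three compounds share the same core and were measured in an assay on HEK293 cells for displacement of a labelled ligand from Melanocortin receptor 4 (Homo sapiens); on this read-out higher numbers stand for weaker inhibition and lower numbers for stronger inhibition. Among them compound 1 has the highest number, meaning the weakest inhibition; compound 2 and compound 3 both stand well below it, beyond the scatter. Compound 4 `CC(C)C[C@H](N)c1cc(C(F)(F)F)ccc1N1CCN(C(=O)COc2ccc(Cl)cc2)CC1` has not yet been measured. It differs from compound 1 in one place: 4-chlorophenyl in place of naphthalen-2-yl on an oxygen on a saturated carbon. Among the measured compounds shown here, no measured step covers exactly this change. For the measured compounds named here, the only step that starts from compound 1 is a 65-fold lower number from compound 1 to compound 3 (1.81 log units; beyond the scatter), and that step exchanges the whole group on the carbonyl carbon, oxygen link included, for one that contains a 4-chlorophenyl. Compound 4 keeps the oxygen on a saturated carbon and only trades naphthalen-2-yl for 4-chlorophenyl, so the change is narrower than in that step. Some movement toward the lower numbers of compound 2 and compound 3 is expected, but less than the full measured gain. Compound 4 is therefore estimated at 400 nM, with a range from 100 nM to 1500 nM, which is expected to amount to a 5.0-fold lower number from compound 1 to compound 4 (0.70 log units; beyond the scatter).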

Compound 4, inhibition constant: 2900 nM
Compound 4: middle estimate off by 7.3-fold (0.86 log units), on the low side; measured number above the stated range.
By their numbers in this assay, from the lowest: compound 3; then compound 2; then compounds 1 and 4 (each within the scatter of the next).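

In this assay, 4-chlorophenyl in place of naphthalen-2-yl on the oxygen gives a 1.5-fold higher number from compound 1 to compound 4 (0.16 log units; within the scatter) and so lies within the scatter, which means that on this oxygen link the single ring and the double ring cannot be told apart. The 4-chlorophenyl ring alone therefore does not bring the strength seen in compound 3: with that ring present in both compounds, (4-chlorophenoxy)methyl in place of 1-(4-chlorobenzyl)ethyl on the carbonyl carbon gives a 94-fold higher number from compound 3 to compound 4 (1.97 log units; beyond the scatter) as a large loss. Still open, on these data alone, is which part of that exchange matters, the oxygen or the methyl branch, since the two compounds differ in both. Also open, as far as these compounds go, is what a longer chain before the ring would do, or a nitrile or an amine in place of the chlorine. Nothing measured here explains these results.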